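The source may report more compounds than this note shows. Statements on the series, on what has been measured and on what is new or still open speak of the compounds shown alone.

Compound 2 `O=C(O)/C(S)=C/c1c[nH]c2cc(Cl)ccc12` carries a chloro group on the six-membered aromatic ring of its core. In an assay on isolated protein for inhibition of Calpain-1 catalytic subunit (Sus scrofa) (a higher number here means a weaker inhibitor, a lower number a stronger inhibitor), compound 2 gives 100 nM. Its nearest relative, compound 1 `O=C(O)/C(S)=C/c1c[nH]c2cc(Br)ccc12`, carries bromo in the same place, and in this assay compound 1 gives 90 nM. The step of a 1.1-fold higher number from compound 1 to compound 2 (0.05 log units; within the scatter) shows that replacing bromo with chloro barely moves the number. Among the compounds with values here, compound 2 therefore stands at one of two numbers measured so far, and the gap to the other, that of compound 1, falls within the scatter.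

Compound 3 `O=C(O)/C(S)=C/c1c[nH]c2cc(F)ccc12` extends the same series to a third halogen: fluoro in place of chloro on an aromatic carbon. Within the data shown here, only one measured step bears on this kind of change, a 1.1-fold higher number from compound 1 to compound 2 (0.05 log units; within the scatter), and it stayed within the scatter. On that basis the change is expected to produce a step of a 1.5-fold higher number from compound 2 to compound 3 (0.18 log units; within the scatter), small and not clearly beyond the scatter, with any drift more likely toward a higher number than a lower one. Compound 3 is accordingly estimated at 150 nM in this assay, within a range from 60 nM to 400 nM.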

Compound 3, half-maximal inhibitory concentration: 300 nM
The estimate for compound 3 lay 2.0-fold (0.30 log units) below the measured number, within the range that was stated.
By their numbers in this assay, from the lowest: compounds 1 and 2 (each within the scatter of the next); then compound 3.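

In this assay, the halogens at this position are no longer interchangeable: fluoro in place of chloro gives a 3.0-fold higher number from compound 2 to compound 3 (0.48 log units; beyond the scatter) and fluoro in place of bromo gives a 3.3-fold higher number from compound 1 to compound 3 (0.52 log units; beyond the scatter). Both steps are modest, but unlike the swap between bromo and chloro, they lie beyond the scatter, so compound 3 is the weakest inhibitor of the three. This aromatic carbon can therefore register a change of a single halogen atom, even though the change from bromo to chloro could not be told apart from the ordinary variation between repeated measurements, and nothing measured here explains why fluoro stands apart.

The compounds shown leave open what happens at this carbon with a plain hydrogen or with a group that is not a halogen, such as methyl, methoxy or a nitrile, so it cannot yet be said whether fluoro is unusual or bromo and chloro are. They also leave open whether the same three halogens would rank the same way on another carbon of the six-membered ring, since all three sit in one place on the shared core.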